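The source may report more compounds than this note shows. Statements on the series, on what has been measured and on what is new or still open speak of the compounds shown alone.

Three compounds from one study share a common core and differ only in the two aromatic rings attached to it. Compound 1, `C=CCn1c(=O)/c(=C\c2ccc(F)c(Br)c2)[nH]c(=O)/c1=C\c1ccccc1OC`, and compound 2, `C=CCn1c(=O)/c(=C\c2cccc(Br)c2)[nH]c(=O)/c1=C\c1cccc(Br)c1`, were tested in a functional assay on HeLa cells (Homo sapiens) for cytotoxicity, read by CCK-8 assay, with a stated time of 72 h; a higher number here means a weaker inhibitor, a lower number a stronger inhibitor; compound 1 gives "not active" (no number reported) and compound 2 gives "not active" (no number reported), so neither yields a number. For the measured compounds named here, compound 3, `C=CCn1c(=O)/c(=C\c2ccccc2F)[nH]c(=O)/c1=C\c1ccccc1OC`, is the one entry with a measured value: in this assay compound 3 gives 45000 nM, a weak result, and it is the only number against which anything can be set. Compound 4, `C=CCn1c(=O)/c(=C\c2cc(Br)ccc2F)[nH]c(=O)/c1=C\c1ccccc1OC`, has not yet been measured. It differs from compound 3 in a single place: bromo in place of hydrogen on an aromatic carbon, so that a 2-fluorophenyl becomes a 5-bromo-2-fluorophenyl. Going by the values given here, no pair of measured compounds shows this same change, so there is no measured step to lean on. What is known is that compound 1, which also carries a bromo and a fluoro, gives "not active" (no number reported), and compound 2, with two bromo groups, gives "not active" (no number reported). Against that background the step of a 1.3-fold higher number from compound 3 to compound 4 (0.12 log units; within the scatter) is expected to be small and, if anything, toward weaker inhibition, within or just beyond the scatter. Compound 4 is therefore estimated at 60000 nM, with a plausible range from 25000 nM to 150000 nM.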

Compound 4, half-maximal inhibitory concentration: 34600 nM
Compound 4: the middle estimate sits 1.7-fold (0.24 log units) above what was measured; measured number inside the range.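

In this assay, placing a bromo on the 2-fluorophenyl to give a 5-bromo-2-fluorophenyl produces a 1.3-fold lower number from compound 3 to compound 4 (0.11 log units; within the scatter), so at this position the added bromo leaves no change that can be told apart from ordinary variation between repeated measurements. For the compounds shown here, compound 4 is also the only bromo-bearing compound here with a number, which shows that a bromo on these aromatic rings does not by itself mean a "not active" result, although compound 1 and compound 2 each differ from compound 4 in more than one place and cannot be compared with it directly. No measurement shown here offers an explanation for this result.

On these data alone, it remains open what other groups would do on this same aromatic carbon, for example an amine, a carboxylic acid or a longer chain such as a propyl group, any of which could be compared directly with compound 3. Going by these compounds alone, this single pair also cannot show whether the bromo would give a similarly small step when the second aromatic ring is different from the one shared by compound 3 and compound 4.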